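Trading phenyl for furan-3-yl on compound 3

The source may report more compounds than this note shows. Statements on the series, on what has been measured and on what is new or still open speak of the compounds shown alone.

Compound 1 `OC[C@H]1O[C@@H](n2cc(F)c3c(-c4ccccc4)ncnc32)[C@H](O)[C@@H]1O`: 3100 nM
Compound 2 `OC[C@H]1O[C@@H](n2cc(F)c3c(-c4ccsc4)ncnc32)[C@H](O)[C@@H]1O`: 560 nM
Compound 3 `OC[C@H]1O[C@@H](n2cc(Cl)c3c(-c4ccccc4)ncnc32)[C@H](O)[C@@H]1O`: 910 nM

These values come from a functional assay on CCRF-CEM cells (Homo sapiens) for cytotoxicity, read by XTT assay, with a stated time of 3 days; a higher number here means a weaker inhibitor, a lower number a stronger inhibitor. Compound 3, at 910 nM, lies within the usual scatter of compound 2, and both numbers are clearly lower than that of compound 1. The next compound, compound 4 `OC[C@H]1O[C@@H](n2cc(Cl)c3c(-c4ccoc4)ncnc32)[C@H](O)[C@@H]1O`, differs from compound 3 in one place: furan-3-yl in place of phenyl on an aromatic carbon. In words, furan-3-yl stands in place of phenyl on an aromatic carbon.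

The closest guide is a 5.5-fold lower number from compound 1 to compound 2 (0.74 log units; beyond the scatter), a modest step beyond the scatter, where thiophen-3-yl replaced phenyl. That step carried fluoro rather than chloro, and its incoming ring was not furan-3-yl, so it is only a rough guide. The other measured step, a 3.4-fold lower number from compound 1 to compound 3 (0.53 log units; beyond the scatter), swapped fluoro for chloro and says nothing direct about this ring change. Among the measured compounds shown here, no measured compound carries furan-3-yl, so a modest step in the same direction is expected, towards a lower number in this assay. The estimated change is a 3.8-fold lower number from compound 3 to compound 4 (0.58 log units; beyond the scatter). Compound 4 is estimated at 240 nM, with an expected range from 70 nM to 800 nM.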

Compound 4, half-maximal inhibitory concentration: 1100 nM
Beside the measured number, compound 4's estimate is 4.6-fold (0.66 log units) below it; measured number above the stated range.
By their numbers in this assay, from the lowest: compounds 2, 3 and 4 (each within the scatter of the next); then compound 1.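

On the chloro compound, furan-3-yl in place of phenyl gives a 1.2-fold higher number from compound 3 to compound 4 (0.08 log units; within the scatter) in this assay, so at this position the two rings cannot be told apart in this assay. The earlier ring change, a 5.5-fold lower number from compound 1 to compound 2 (0.74 log units; beyond the scatter), brought thiophen-3-yl onto the fluoro compound, and that lower number does not carry over to this new pair, which shows that a five-membered aromatic ring in place of phenyl does not always lower the number here. The two steps differ in both the halogen and the incoming ring, and nothing available explains the contrast.

On these data alone, whether thiophen-3-yl would lower the number on the chloro compound remains open, and so does whether the halogen or the ring accounts for the contrast. As far as these compounds go, how an amine or a morpholine ring at this position would read also remains open.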